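Chloro to methoxy on an aromatic carbon

The source may hold more compounds than are shown below. What is called first, only, known or untested is meant among the compounds shown, and "the series" means these compounds.

compound 1 `O=C(O)COC1CCN(CCN(C(=O)c2ccc(F)cc2)c2ccc(Cl)cc2)CC1`: 2000 nM
compound 2 `O=C(O)COC1CCN(CCN(C(=O)c2ccc(Cl)cc2)c2ccc(Cl)cc2)CC1`: 1500 nM

Both values come from a functional assay on a cell-free system (Platelet, plasma, Homo sapiens) for inhibition; on this read-out higher numbers stand for weaker inhibition and lower numbers for stronger inhibition. Among the compounds with values here, with only these two numbers, compound 2 at 1500 nM cannot be separated from compound 1, as the one measured step, a 1.3-fold lower number from compound 1 to compound 2 (0.12 log units; within the scatter), lies within the scatter. That step is chloro in place of fluoro on an aromatic carbon.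

Compound 3 `COc1ccc(C(=O)N(CCN2CCC(OCC(=O)O)CC2)c2ccc(Cl)cc2)cc1` has not yet been measured. It differs from compound 2 by methoxy in place of chloro on an aromatic carbon, which is methoxy in place of chloro on an aromatic carbon, para to a large group.

Within the data shown here, the only guide is a 1.3-fold lower number from compound 1 to compound 2 (0.12 log units; within the scatter), and it also replaces a group on an aromatic carbon. Among the measured compounds shown here, no measured step brings in methoxy, so the evidence is thin and the range has to stay wide. No step beyond the scatter is expected in this assay, and no direction can be argued from the data. The expected step is no change at the digits printed from compound 2 to compound 3 (within the scatter). For compound 3 the estimated value is 1500 nM, with an expected range of 600 nM to 3800 nM.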

Compound 3, half-maximal inhibitory concentration: 3100 nM
For compound 3 the middle estimate is 2.1-fold (0.32 log units) below the measured one; measured number inside the range.
By their numbers in this assay, from the lowest: compounds 2, 1 and 3 (each within the scatter of the next, the first and the last beyond it).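

In this assay, within the data shown here, methoxy in place of chloro, para to a large group, gives a 2.1-fold higher number from compound 2 to compound 3 (0.32 log units; beyond the scatter) and is the first step to pass the scatter, so this position is not indifferent to the group it carries, though the effect is modest. Methoxy is not separated from fluoro at the same position, since a 1.6-fold higher number from compound 1 to compound 3 (0.19 log units; within the scatter) stays within the scatter; the change is therefore visible only against the chloro of compound 2, and this single pair carries the whole reading. Nothing at hand accounts for the step between chloro and methoxy.

Open, from the compounds shown here alone, is whether the higher number belongs to methoxy itself or would recur with a hydroxy group, an amine or a longer alkoxy chain at this position. Also open, going by these compounds, is whether the same exchange of chloro for methoxy would read the same elsewhere on the shared core, as all three compounds differ only at this one place.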